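The source may hold more compounds than are shown below. What is called first, only, known or untested is meant among the compounds shown, and "the series" means these compounds.

Within the data shown here, compound 2 `CC(C)(C)CC(=O)OC1C(C(O)CO)OC2OC(C)(C)OC21` gives 1200000 nM in a functional assay on K562 cells (Homo sapiens) for inhibition (on this read-out higher numbers stand for weaker inhibition and lower numbers for stronger inhibition), the second highest of the three numbers so far: compound 1 `CC(=O)OC1C(C(O)CO)OC2OC(C)(C)OC21` gives 3800000 nM and compound 3 `CC(CC(=O)OC1C(C(O)CO)OC2OC(C)(C)OC21)c1ccccc1` gives 500000 nM. Compound 4 `CC1(C)OC2OC(C(O)CO)C(OC(=O)C3CCCC3)C2O1` differs from compound 2 by cyclopentyl in place of neopentyl on a carbonyl carbon. The steps seen so far all alter a saturated chain carbon bound to a carbonyl carbon: a 3.2-fold lower number from compound 1 to compound 2 (0.50 log units; beyond the scatter), a 7.6-fold lower number from compound 1 to compound 3 (0.88 log units; beyond the scatter) and a 2.4-fold lower number from compound 2 to compound 3 (0.38 log units; beyond the scatter). None of them exchanges a branched chain for a ring, so their bearing is indirect; the entering and leaving groups match in heavy-atom count, and a step within the scatter is expected, a 1.2-fold lower number from compound 2 to compound 4 (0.08 log units; within the scatter). Compound 4 is therefore estimated at 1000000 nM, with a range from 400000 nM to 2500000 nM.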

Compound 4, half-maximal inhibitory concentration: 2500000 nM
Compound 4: the middle estimate sits 2.5-fold (0.40 log units) below what was measured, and the stated range covers the measured number.
By their numbers in this assay, from the lowest: compound 3; then compound 2; then compounds 4 and 1 (each within the scatter of the next).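

Cyclopentyl in place of neopentyl on a carbonyl carbon gives a 2.1-fold higher number from compound 2 to compound 4 (0.32 log units; beyond the scatter) with the same heavy-atom count on both sides, so at this position the ring and the open chain are not interchangeable. Cyclopentyl in place of methyl gives a 1.5-fold lower number from compound 1 to compound 4 (0.18 log units; within the scatter) despite the larger heavy-atom count, so that count alone does not set the number here. Nothing available explains the ring result. Open, going by these compounds, is whether cyclohexyl, phenyl or a longer chain on the carbonyl carbon would fall nearer compound 3 or compound 4, and whether an amine on the cyclopentyl ring would move the number.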